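Lengthening the Alkoxy Chain of an Aryl Amide

A few compounds are considered here, and "the series" means these few. Any claim that something is new, unique, unknown or untested is made for them only; others in the source may bear on it.

Three compounds have numbers in an assay on isolated protein for agonist activity at Bile acid receptor (Homo sapiens), read by TR-FRET, with a stated time of 3 h, in the absence of a further agent; a lower number here means that less compound is needed, a higher number that more compound is needed for the effect. Compound 1 `O=C(O)COc1cccc(NC(=O)c2ccc(Oc3ccccc3)cc2)c1` reaches only a limit of the assay, giving > 10000 nM; this is the case noted as the limit of > 10000 nM in this assay, at which 1 of the 3 values shown sits. Compound 2 `Cc1ccc(NC(=O)c2ccc(Oc3ccccc3)cc2)cc1C(=O)O` gives 127 nM. Compound 3 `CCOc1cccc(C(=O)Nc2cccc(C(=O)O)c2)c1` gives 2350 nM, the higher of the two numbers, and the gap to compound 2 lies beyond the usual scatter.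

Compound 4 `CCCCCOc1cccc(C(=O)Nc2cccc(C(=O)O)c2)c1` differs from compound 3 in one place: propyl in place of hydrogen on a saturated chain carbon, two bonds along the chain from an oxygen on an aromatic ring, so that ethoxy becomes pentyloxy. Among the compounds with values here, no pair among the measured compounds shows the effect of such a lengthening, so there is nothing to lean on except the change itself. In this assay the step is expected to be small, a 1.6-fold lower number from compound 3 to compound 4 (0.19 log units; within the scatter), with a modest move toward a lower number considered the more likely outcome but not assured. Compound 4 is therefore expected to give about 1500 nM, with a plausible range from 400 nM to 6000 nM.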

Compound 4, half-maximal effective concentration: 2540 nM
Beside the measured number, compound 4's estimate is 1.7-fold (0.23 log units) below it; the measured number falls inside the stated range.
By their numbers in this assay, from the lowest: compound 2; then compounds 3 and 4 (each within the scatter of the next). At a limit, above all of these: compound 1.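

Within the data shown here, the lengthening of ethoxy to pentyloxy is the first one-place comparison, and in this assay it gives a 1.1-fold higher number from compound 3 to compound 4 (0.03 log units; within the scatter). Compound 3 and compound 4 therefore cannot be told apart in this assay: at this saturated chain carbon, two bonds along the chain from an oxygen on an aromatic ring, the added propyl leaves the reading within the scatter. The compounds shown offer no measurement that explains this result.

As far as these compounds go, it remains open whether a chain longer than pentyloxy, or an amine or a hydroxyl group carried on this chain, would stay within the scatter of compound 3. Also open, from the compounds shown here alone, is whether a cyclohexyl or phenyl group at this place would give a clearly different number.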